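The compounds below may be only part of what the source reports. "The series", "measured", "known", "first", "only" and "open" are said of these compounds alone.

Measured in a functional assay on A549 cells (Homo sapiens) for antiproliferative activity, read by MTT assay, with a stated time of 24 h; a lower number here means a stronger inhibitor, a higher number a weaker inhibitor:
- compound 1 `O=C(NNc1ccccc1Cl)c1ccc(NS(=O)(=O)c2cnc(O)nc2O)cc1`: 3340 nM
- compound 2 `CCCCOc1ccc(C(=O)NNC(=O)c2ccc(NS(=O)(=O)c3cnc(O)nc3O)cc2)cc1`: 9010 nM

Of these two compounds, compound 2 stands highest at 9010 nM, and its gap to compound 1 lies beyond the scatter. The next compound is compound 3 `O=C(NNC(=O)c1ccccc1F)c1ccc(NS(=O)(=O)c2cnc(O)nc2O)cc1`, with 2-fluorophenyl in place of 4-butoxyphenyl on a carbonyl carbon. For the measured compounds named here, no measured pair differs in only one place, so this change has no direct precedent in the data. Going by the values given here, the sole lower reference is compound 1 at 3340 nM, which also carries no 4-butoxyphenyl. A modest move toward a lower number in this assay is therefore expected, near the edge of the scatter. The expected change is a 1.8-fold lower number from compound 2 to compound 3 (0.26 log units; within the scatter). For compound 3 the estimated value is 5000 nM, with an expected range of 1800 nM to 14000 nM.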

Compound 3, half-maximal inhibitory concentration: 7610 nM
Estimate against measurement, compound 3: 1.5-fold (0.18 log units) below; the range from low to high includes it.
By their numbers in this assay, from the lowest: compound 1; then compounds 3 and 2 (each within the scatter of the next).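

In this assay, 2-fluorophenyl in place of 4-butoxyphenyl on a carbonyl carbon gives a 1.2-fold lower number from compound 2 to compound 3 (0.07 log units; within the scatter), so this position tolerates the loss of the 4-butoxyphenyl group with no readable effect on the number. (2-Fluorophenyl)carbonyl in place of 2-chlorophenyl on an amine nitrogen gives a 2.3-fold higher number from compound 1 to compound 3 (0.36 log units; beyond the scatter), a modest step that ties the gap to a single place in the series. No measured evidence on the origin of either step is available.

This step changes both the carbonyl and the aryl group, so the share of each remains unresolved. Also open, as far as these compounds go, is whether an aminophenyl or carboxyphenyl group on the carbonyl carbon, or a longer alkoxy chain on the phenyl ring, would stay within the scatter of compound 3.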